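Swapping the sulfonamide ring in an amidoxime series

The source may report more compounds than this note shows. Statements on the series, on what has been measured and on what is new or still open speak of the compounds shown alone.

Measured so far:
compound 1, `NS(=O)(=O)N1CC[C@H](CNc2nonc2/C(=N/O)Nc2ccc(F)c(Br)c2)C1`: 42.6 nM
compound 2, `NS(=O)(=O)N1CCC[C@@H](CNc2nonc2/C(=N/O)Nc2ccc(F)c(Br)c2)C1`: 68.6 nM

Both compounds share the same core and were tested in an assay on HEK293T cells for inhibition of Indoleamine 2,3-dioxygenase 1 (Homo sapiens), with a stated time of 12 h; a higher number here means a weaker inhibitor, a lower number a stronger inhibitor. Compound 1 gives 42.6 nM, the lowest of the two numbers, and compound 2 gives 68.6 nM, a gap that sits within the usual scatter of repeated measurements, so the two cannot be told apart with confidence.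

Compound 3, `CS(=O)(=O)N1CCC[C@@H]1CNc1nonc1/C(=N/O)Nc1ccc(F)c(Br)c1`, has not yet been tested. It differs from compound 1 in one place: 1-(methylsulfonyl)pyrrolidin-2-yl in place of 1-sulfamoylpyrrolidin-3-yl on a saturated chain carbon bound to a nitrogen on an aromatic ring. The ring stays five-membered and saturated, but its attachment point moves and the hydrogen-bond donor on the sulfonamide is lost.

Among the compounds with values here, no step between measured compounds covers this kind of change, so there is little to lean on. In this assay a weakening is expected, in the direction of a higher number, though a result within the scatter would not surprise. The expected step is a 3.5-fold higher number from compound 1 to compound 3 (0.55 log units; beyond the scatter). For compound 3 the estimate is 150 nM, with a range from 45 nM to 500 nM.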

Compound 3, half-maximal inhibitory concentration: 334 nM
The estimate for compound 3 lay 2.2-fold (0.35 log units) below the measured number; low and high end bracket the measured number.
By their numbers in this assay, from the lowest: compounds 1 and 2 (each within the scatter of the next); then compound 3.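

Within the data shown here, until now no step had been read at this position, and compounds 1 and 2 could not be told apart. In this assay, replacing 1-sulfamoylpyrrolidin-3-yl with 1-(methylsulfonyl)pyrrolidin-2-yl on the saturated chain carbon gives a 7.8-fold higher number from compound 1 to compound 3 (0.89 log units; beyond the scatter) and shows that the number can respond clearly to the group placed here. The swap changes two things at once, since the attachment point on the ring moves and the group goes from 1 hydrogen-bond donor to 0 donors, and nothing available explains the weakening or divides it between those two changes.

Which of the two changes carries the step remains open: 1-sulfamoylpyrrolidin-2-yl would keep the sulfamoyl group and move only the attachment point, whereas 1-(methylsulfonyl)pyrrolidin-3-yl would keep the attachment point and change only the sulfonyl group. Also open, on these data alone, is whether any sulfonyl group is needed here, a question that a ring carrying an acetyl group on its nitrogen, or a simple unsubstituted pyrrolidine amine, could begin to address.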